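Carbamate in place of pyrimidine on the piperidine nitrogen

A few compounds are considered here, and "the series" means these few. Any claim that something is new, unique, unknown or untested is made for them only; others in the source may bear on it.

Measured compounds:
compound 1 `CCNC(=O)c1ccc(-c2cc3nnn(C4CCN(c5ncc(CC)cn5)CC4)c3cn2)c(F)c1` 15 nM
compound 2 `CCNC(=O)c1cc(F)c(-c2cc3nnn(C4CCN(c5ncc(CC)cn5)CC4)c3cn2)cc1F` 2 nM

In a functional assay on HEK293 cells for agonist activity at Glucose-dependent insulinotropic receptor (Homo sapiens), read by HTRF and cAMP accumulation, with a stated time of 30 min (on this read-out lower numbers stand for an effect already at smaller amounts and higher numbers for an effect only at larger amounts of compound), compound 2 gives 2 nM, the lowest of the two numbers; the nearest is compound 1 at 15 nM, and the step of a 7.5-fold lower number from compound 1 to compound 2 (0.88 log units; beyond the scatter) lies beyond the scatter. Compound 3 `CCNC(=O)c1cc(F)c(-c2cc3nnn(C4CCN(C(=O)OC(C)C)CC4)c3cn2)cc1F` differs from compound 2 by isopropoxycarbonyl in place of 5-ethylpyrimidin-2-yl on an amine nitrogen in a ring. Among the compounds with values here, the one measured step concerns a fluorine on an aromatic carbon and does not touch this position, so no measured step bears on the change. With nothing to anchor the direction, the expected step for compound 3 is a 5.0-fold higher number from compound 2 to compound 3 (0.70 log units; beyond the scatter), with wide uncertainty. The estimate for compound 3 in this assay is 10 nM, between 2 nM and 60 nM.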

Compound 3, half-maximal effective concentration in the Glucose-dependent insulinotropic receptor assay: 37 nM
For compound 3 the middle estimate is 3.7-fold (0.57 log units) below the measured one; the range from low to high includes it.
By their numbers in the Glucose-dependent insulinotropic receptor assay, from the lowest: compound 2; then compound 1; then compound 3.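

On the amine nitrogen in a ring, an aromatic group is not required for activity, but the choice of group matters: in the Glucose-dependent insulinotropic receptor assay, isopropoxycarbonyl in place of 5-ethylpyrimidin-2-yl gives a 19-fold higher number from compound 2 to compound 3 (1.27 log units; beyond the scatter). The same change moves the value in a physicochemical assay for solubility, read by HPLC, in phosphate buffer, measured as thermodynamic solubility, with a stated time of 24 h, at pH 6.8 (a higher number here means a more soluble compound, a lower number a less soluble compound), in the opposite sense, from compound 2 at 240 nM to compound 3 at 5500 nM, so a loss in one is set against a gain in the other: the measured solubility of compound 2, 240 nM, and of compound 3, 5500 nM, a 23-fold higher number (1.36 log units; beyond the scatter)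

Open, going by these compounds, is whether another group on this nitrogen, such as tert-butoxycarbonyl, cyclopropoxycarbonyl or a urea, would keep the solubility of compound 3 while approaching compound 2 in the Glucose-dependent insulinotropic receptor assay.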